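This account rests on a few compounds, and the source may have more. Where it says the series, first, only, none or still open, it means among the compounds named here.

In a functional assay on microsomes from liver (Rattus norvegicus) for inhibition (on this read-out higher numbers stand for weaker inhibition and lower numbers for stronger inhibition), compound 2 `COc1ccc2c(c1)CCC(Cc1ccc(O)cc1)C2=O` gives 400 nM. Compound 3 `O=C1c2ccc(O)cc2CCC1Cc1ccc(O)cc1` gives 1500 nM. The change from compound 2 to compound 3 is hydrogen in place of methyl on an oxygen on an aromatic ring, and it brought a 3.8-fold higher number from compound 2 to compound 3 (0.57 log units; beyond the scatter). Compound 1 `COc1ccc2c(c1)CC/C(=C\c1ccccc1Br)C2=O` carries the same methoxy group on a different core; how the two cores differ is not broken down here. In this assay compound 1 reached only a limit, > 20000 nM. Compound 4 `O=C1/C(=C/c2ccccc2Br)CCc2cc(O)ccc21` differs from compound 1 by hydrogen in place of methyl on an oxygen on an aromatic ring, the same change as between compound 2 and compound 3, made at a place described in the same words. Compound 4 is expected to move by a step that the limit leaves unreadable from compound 1 to compound 4 because the limit of > 20000 nM in this assay, at which 1 of the 3 values shown sits, already holds compound 1 at the edge of what the assay reports, so the number is likely to stay a limit. Compound 4 is estimated at 60000 nM, between 20000 nM and 250000 nM.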

Compound 4, half-maximal inhibitory concentration: 2400 nM
Estimate against measurement, compound 4: 25-fold (1.40 log units) above, outside the stated range (below it).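

In this assay the change from methoxy to hydroxy brought an at least 8.3-fold lower number from compound 1 to compound 4 (0.92 log units; beyond the scatter) on the core of compound 1. Compound 1 stands at > 20000 nM as a limit and not a number, so this step has a bound and no exact size. Set beside the earlier step, the change does not carry over from one core to the other in this series, and these two pairs do not show which difference between the cores decides its direction: the same change on two cores in this assay, a 3.8-fold higher number (0.57 log units; beyond the scatter) from compound 2 to compound 3 and an at least 8.3-fold lower number (0.92 log units; beyond the scatter) from compound 1 to compound 4, at least 31-fold (1.49 log units) apart, beyond the scatter of two such steps.

Which part of the two cores sets that direction remains open. Going by these compounds, it is also open whether an ethoxy group, an amine or a carboxylic acid in place of the methoxy group would follow compound 3 or compound 4.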